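From allyl to benzoyl on compound 1

A few compounds are considered here, and "the series" means these few. Any claim that something is new, unique, unknown or untested is made for them only; others in the source may bear on it.

Measured in an ADME assay on HEK293 cells (Homo sapiens) for cytotoxicity, read by resazurin assay, with a stated time of 16 h; a higher number here means that more compound is needed for the effect, a lower number that less compound is needed:
compound 1 `C=CCOc1ccc(/C=C/C(=O)CC(=O)/C=C/c2ccc(O)c(OC)c2)cc1OC` gives 270000 nM
compound 2 `C=CCOc1ccc(/C=C/C(=O)CC(=O)/C=C/c2ccc(OCC=C)c(OC)c2)cc1OC` gives > 500000 nM, which is a limit and not a number
compound 3 `COc1cc(/C=C/C(=O)CC(=O)/C=C/c2cc(OC)c(O)c([N+](=O)[O-])c2)ccc1O` gives 82000 nM

Among the measured compounds shown here, of the two true numbers, the one for compound 1 is the higher, and compound 3 lies lower by more than the scatter. Compound 2 gives no number to compare, as the limit of > 500000 nM in this assay, at which 1 of the 3 values shown sits, shows.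

Compound 4 `COc1cc(/C=C/C(=O)CC(=O)/C=C/c2ccc(OC(=O)c3ccccc3)c(OC)c2)ccc1O` has not yet been measured. Its difference from compound 1 is benzoyl in place of allyl on an oxygen on an aromatic ring, so benzoyl stands in place of allyl on an oxygen on an aromatic ring.

For the measured compounds named here, only one measured step bears on this, and only loosely: an at least 1.8-fold higher number from compound 1 to compound 2 (0.26 log units; that floor lies within the scatter). That step puts allyl in place of hydrogen, so it is not the same exchange, and its size is a floor within the scatter. It therefore gives no ground for expecting a clear move in either direction in this assay. A small lean towards a lower number is allowed, since compound 3 at 82000 nM shows that lower numbers occur among these compounds.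

The expected change is a 1.5-fold lower number from compound 1 to compound 4 (0.18 log units; within the scatter) and, as an estimate, it stays within the scatter. For compound 4 the estimated value is 180000 nM with an expected range from 60000 nM to 450000 nM.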

Compound 4, half-maximal effective concentration: 94000 nM
Compound 4: middle estimate off by 1.9-fold (0.28 log units), on the high side; low and high end bracket the measured number.
By their numbers in this assay, from the lowest: compounds 3 and 4 (each within the scatter of the next); then compound 1. At a limit, above all of these: compound 2.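

In this assay, benzoyl in place of allyl on an oxygen on an aromatic ring gives a 2.9-fold lower number from compound 1 to compound 4 (0.46 log units; beyond the scatter), so the group held on this oxygen can shift the number by more than the scatter. Among the compounds shown here, the one earlier step at such an oxygen could not show this: it reads an at least 1.8-fold higher number from compound 1 to compound 2 (0.26 log units; that floor lies within the scatter), and it puts allyl in place of hydrogen, which is a different exchange. The change brings in a six-membered aromatic ring of carbon and one hydrogen-bond acceptor, and removes a chain with a double bond, but this single step cannot tell which of these parts goes with the lower number.

Going by these compounds, it remains open whether other groups on this oxygen, such as an acetyl group, a longer chain or a chain ending in an amine, would move the number in the same direction as benzoyl, and whether a benzoyl ring carrying a further group would go further. Compound 2 stands as a limit and not a number, which leaves the true size of the step to it open: the limit of > 500000 nM in this assay, at which 1 of the 4 values shown sits.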